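Piperidin-4-yl on the aromatic nitrogen

The compounds below may be only part of what the source reports. "The series", "measured", "known", "first", "only" and "open" are said of these compounds alone.

In a functional assay on HT-29 cells (Homo sapiens) for inhibition, read by luminescence and CellTiter-Glo, with a stated time of 24 h (on this read-out lower numbers stand for an effect already at smaller amounts and higher numbers for an effect only at larger amounts of compound), compound 1 (`CN1C(=S)[C@@H](NC(=O)c2nc(Cc3ccccc3)n(CCCC#N)n2)COc2ccccc21`), with 3-cyanopropyl on an aromatic nitrogen, gives 2400 nM. With cycloheptyl in that place, compound 2 (`CN1C(=S)[C@@H](NC(=O)c2nc(Cc3ccccc3)n(C3CCCCCC3)n2)COc2ccccc21`) gives 5530 nM.

Compound 3 (`CN1C(=S)[C@@H](NC(=O)c2nc(Cc3ccccc3)n(C3CCN(C(=O)OC(C)(C)C)C3)n2)COc2ccccc21`) gives > 10000 nM, which is a limit of the assay and not a number. For compound 3 this is the limit of > 10000 nM in this assay, at which 1 of the 3 values shown sits.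

Compound 4 (`CN1C(=S)[C@@H](NC(=O)c2nc(Cc3ccccc3)n(C3CCNCC3)n2)COc2ccccc21`) changes the same place: a group of 6 heavy atoms (5 carbon, 1 nitrogen; one six-membered non-aromatic ring with 1 hetero atom) in place of a group of 12 heavy atoms (9 carbon, 1 nitrogen, 2 oxygen; one five-membered non-aromatic ring with 1 hetero atom), on an aromatic nitrogen. Piperidin-4-yl is the entering group.

Within the data shown here, no measured step makes this exact change, but three steps concern the same nitrogen: a 2.3-fold higher number from compound 1 to compound 2 (0.36 log units; beyond the scatter), an at least 4.1-fold higher number from compound 1 to compound 3 (0.61 log units; beyond the scatter) and an at least 1.8-fold higher number from compound 2 to compound 3 (0.25 log units; that floor lies within the scatter). The entering group is close in heavy-atom count to the groups of compound 1 and compound 2, so compound 4 is expected to read nearer those two values. A modest move to a lower number is therefore expected in this assay, though a second reading at the limit remains possible.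

The expected change is an at least 2.0-fold lower number from compound 3 to compound 4 (0.30 log units; that floor lies within the scatter). Compound 4 is estimated at 5000 nM, with an expected range of 1500 nM to 10000 nM.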

Compound 4, half-maximal effective concentration: 1000 nM
For compound 4 the middle estimate is 5.0-fold (0.70 log units) above the measured one; measured number below the stated range.
By their numbers in this assay, from the lowest: compound 4; then compound 1; then compound 2. At a limit, above all of these: compound 3.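

In this assay, piperidin-4-yl on the aromatic nitrogen gives the lowest number of the four compounds, with a 2.4-fold lower number from compound 1 to compound 4 (0.38 log units; beyond the scatter) and a 5.5-fold lower number from compound 2 to compound 4 (0.74 log units; beyond the scatter); among the compounds shown, this is the first replacement of 3-cyanopropyl that lowers the number rather than raising it. Cycloheptyl and piperidin-4-yl both place a ring on this nitrogen, so a ring there does not by itself set the number, and an at least 10-fold lower number from compound 3 to compound 4 (1.00 log units; beyond the scatter) adds that the group of compound 3 and piperidin-4-yl also lie far apart, although this step is only a floor. The value of compound 3 is a limit of the assay and not a number: the limit of > 10000 nM in this assay, at which 1 of the 4 values shown sits.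

The groups of compound 3 and compound 4 differ both in ring size and in what the ring nitrogen carries, so the step between them does not separate these two changes. As far as these compounds go, it remains open how the number responds to pyrrolidin-3-yl with a free ring nitrogen, to 1-methylpiperidin-4-yl, or to an open-chain amine such as 4-aminobutyl, and so whether the ring, its nitrogen or the hydrogen on that nitrogen goes with the lower number.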